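Swapping the Acid Group on a Peroxide Core

The source may report more compounds than this note shows. Statements on the series, on what has been measured and on what is new or still open speak of the compounds shown alone.

Compound 1 has the structure `CC(C)(Oc1ccc([C@H]2CC[C@]3(CC2)OOC2(O3)C3CC4CC(C3)CC2C4)cc1)C(=O)O`. In a physicochemical assay for solubility, read by nephelometry, in phosphate buffer, measured as kinetic solubility, with a stated time of 30 min, at pH 6.5 (a higher number here means a more soluble compound, a lower number a less soluble compound), compound 1 gives < 1.6 ug/mL, which is a limit of the assay rather than a measured number. Two close relatives are known. Compound 2, `O=C(O)COc1ccc([C@H]2CC[C@]3(CC2)OOC2(O3)C3CC4CC2CC(C3)C4O)cc1`, gives < 1.6 ug/mL in this assay, again a limit. Compound 3, `O=C(O)COc1ccc([C@H]2CC[C@]3(CC2)OOC2(O3)C3CC4CC2CC(C3)C4(F)F)cc1`, gives < 1.6 ug/mL in this assay, also a limit. All three share (the limit of < 1.6 ug/mL in this assay, at which 3 of the 3 values shown sit), so compound 1 cannot be placed above or below its relatives; it sits with them at the floor of what this assay can report.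

Compound 4, `CS(=O)(=O)NC(=O)COc1ccc([C@H]2CC[C@]3(CC2)OOC2(O3)C3CC4CC(C3)CC2C4)cc1`, has not yet been measured. It differs from compound 1 in one place: ((methylsulfonyl)carbamoyl)methyl in place of 1-carboxy-1-methylethyl on an oxygen on an aromatic ring. For the measured compounds named here, no step between measured compounds exists to guide the size of this change, and no measured property of either group is available. The expected step in this assay is a step that the limit leaves unreadable from compound 1 to compound 4, which is none beyond the scatter. Compound 4 is expected to give about 1.5 ug/mL in this assay, with a range from 0.5 ug/mL to 5 ug/mL, and the assay is expected most often to report only a limit again.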

Compound 4, solubility: < 1.6 ug/mL
Compound 4 ended at the assay's limit; the forecaster's own chance of this, stated with the estimate: 70%; the middle value lies beyond the limit too.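

For the compounds shown here, no step from compound 1 to compound 4 can be read, because both stop at a limit of this assay rather than at a number: the limit of < 1.6 ug/mL in this assay, at which 4 of the 4 values shown sit. The compounds shown leave open whether ((methylsulfonyl)carbamoyl)methyl in place of 1-carboxy-1-methylethyl changes solubility at all, and how far any compound lies beyond that limit.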